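Replacing the methoxyphenyl with a chloro methanesulfonamide phenyl

A few compounds are considered here, and "the series" means these few. Any claim that something is new, unique, unknown or untested is made for them only; others in the source may bear on it.

Three measured compounds share one core and differ in the group on a nitrogen at one end. Compound 1 `O=C(Nc1ccc(-c2noc(-c3cccc(NS(=O)(=O)c4ccccc4)c3)n2)c(Cl)c1)c1cccnc1` carries a phenylsulfonyl group there. In a functional assay on MDA-MB-231 cells (Homo sapiens) for antiproliferative activity, read by MTT assay, with a stated time of 72 h (on this read-out higher numbers stand for weaker inhibition and lower numbers for stronger inhibition), compound 1 gives only a limit, > 10000 nM. Compound 2 `COc1cccc(S(=O)(=O)Nc2cccc(-c3nc(-c4ccc(NC(=O)c5cccnc5)cc4Cl)no3)c2)c1` has a methoxy in place of hydrogen on an aromatic carbon of that group; in this assay compound 2 also gives a limit, > 10000 nM. Among the compounds with values here, compound 3 `COc1cccc(NC(=O)Nc2cccc(-c3nc(-c4ccc(NC(=O)c5cccnc5)cc4Cl)no3)c2)c1` has (3-methoxyphenyl)carbamoyl in place of phenylsulfonyl on the nitrogen, and in this assay compound 3 gives 6700 nM, the only real number among the three. The steps of an at least 1.4-fold lower number from compound 1 to compound 3 (0.17 log units; that floor lies within the scatter) and an at least 1.4-fold lower number from compound 2 to compound 3 (0.17 log units; that floor lies within the scatter) are read against the limit of > 10000 nM in this assay, at which 2 of the 3 values shown sit, and so show only a floor, not a size. The step that the two limits leave unreadable from compound 1 to compound 2 cannot be read at all.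

Compound 4 `CS(=O)(=O)Nc1ccc(NC(=O)Nc2cccc(-c3nc(-c4ccc(NC(=O)c5cccnc5)cc4Cl)no3)c2)cc1Cl` keeps the carbamoyl link; the change is 3-chloro-4-(methanesulfonamido)phenyl in place of 3-methoxyphenyl on an amide-type nitrogen. Within the data shown here, none of the measured steps alters this part of the molecule, so no measured step fixes the size of the shift to expect. The number is expected to stay roughly where compound 3 sits, with a 1.5-fold lower number from compound 3 to compound 4 (0.17 log units; within the scatter) as the expected step. Compound 4 is therefore estimated at 4500 nM, within a range from 1200 nM to 15000 nM.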

Compound 4, half-maximal inhibitory concentration: 600 nM
The estimate for compound 4 lay 7.5-fold (0.88 log units) above the measured number; measured number outside the range, below it.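

The group on the amide-type nitrogen turns out to matter in this assay: with the carbamoyl link held fixed, 3-chloro-4-(methanesulfonamido)phenyl in place of 3-methoxyphenyl gives an 11-fold lower number from compound 3 to compound 4 (1.05 log units; beyond the scatter). Within the data shown here, this is the first step with a readable size beyond the scatter, since the earlier steps all rest on a limit: the limit of > 10000 nM in this assay, at which 2 of the 4 values shown sit. The entering group has 12 heavy atoms against 8 and 1 hydrogen-bond donor against 0, but its chlorine and its methanesulfonamido part arrive together, so this one step cannot say which of them accounts for the lower number.

Still open, on these data alone, is whether the chlorine alone or the methanesulfonamido part alone would give a similar drop, and whether this group would have the same effect with the sulfonyl link of compound 1 and compound 2 in place of the carbamoyl link. Also open, as far as these compounds go, is how a phenyl ring carrying an amine or a carboxylic acid would compare on this same nitrogen.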